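Working notes: aromatic substituent changes in the series

The source may hold more compounds than are shown below. What is called first, only, known or untested is meant among the compounds shown, and "the series" means these compounds.

Measured in a functional assay on SKHep cells (Homo sapiens) for antiproliferative activity, read by MTT assay, with a stated time of 12 h; on this read-out higher numbers stand for weaker inhibition and lower numbers for stronger inhibition:
compound 1 `COc1cc(OC)c2c(=O)cc(/C=C/c3ccccc3)oc2c1` gives 26000 nM
compound 2 `COc1cc(OC)c2c(=O)cc(/C=C/c3ccc(F)cc3)oc2c1` gives 29200 nM
compound 3 `COc1cc(OC)c2c(=O)cc(/C=C/c3ccc(Br)cc3)oc2c1` gives > 40000 nM, a limit of the assay and not a number

Compound 3 sits at the limit of > 40000 nM in this assay, at which 1 of the 3 values shown sits; in this assay it has no number, only that limit. The step of a 1.1-fold higher number from compound 1 to compound 2 (0.05 log units; within the scatter) lies within the scatter, and so do an at least 1.5-fold higher number from compound 1 to compound 3 (0.18 log units; that floor lies within the scatter) and an at least 1.3-fold higher number from compound 2 to compound 3 (0.13 log units; that floor lies within the scatter). Compound 4 `COc1cc(OC)c2c(=O)cc(/C=C/c3ccc(OC(F)(F)F)cc3)oc2c1` differs from compound 3 by trifluoromethoxy in place of bromo on an aromatic carbon. The steps bearing on this change are an at least 1.5-fold higher number from compound 1 to compound 3 (0.18 log units; that floor lies within the scatter) and an at least 1.3-fold higher number from compound 2 to compound 3 (0.13 log units; that floor lies within the scatter); neither reaches beyond the scatter, and both end at the limit. For compound 4 the expected step in this assay is therefore a number no higher from compound 3 to compound 4 (the limit leaves the size open), nothing beyond the scatter. Compound 4 is estimated at 40000 nM, between 20000 nM and 80000 nM, with a real chance that only a limit is reported.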

Compound 4, half-maximal inhibitory concentration: 12500 nM
For compound 4 the middle estimate is 3.2-fold (0.51 log units) above the measured one, outside the stated range (below it).
By their numbers in this assay, from the lowest: compound 4; then compounds 1 and 2 (each within the scatter of the next). At a limit, above all of these: compound 3.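

In this assay, within the data shown here, trifluoromethoxy is the first group at this position to give a step beyond the scatter, and that step is towards stronger inhibition (a 2.1-fold lower number from compound 1 to compound 4 (0.32 log units; beyond the scatter); a 2.3-fold lower number from compound 2 to compound 4 (0.37 log units; beyond the scatter)). The step from the bromo compound is also beyond the scatter (an at least 3.2-fold lower number from compound 3 to compound 4 (0.50 log units; beyond the scatter)), so the larger group here does not go with a higher number. Compound 3 remains a limit of the assay and not a number: the limit of > 40000 nM in this assay, at which 1 of the 4 values shown sits.

Still open, on these data alone, is whether the gain follows the oxygen or the fluorines of trifluoromethoxy. Methoxy or trifluoromethyl at this position would separate the two.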